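Removing trifluoromethoxy from compound 2: an expected step

The compounds below may be only part of what the source reports. "The series", "measured", "known", "first", "only" and "open" are said of these compounds alone.

Values in a functional assay on NIH3T3 cells (Mus musculus) (on this read-out lower numbers stand for an effect already at smaller amounts and higher numbers for an effect only at larger amounts of compound), so far
- compound 1 `Cn1cncc1C(OCc1nc(N2CCC(O)CC2)c(C#N)cc1-c1cccc(Cl)c1)c1ccc(C#N)cc1` gives 3.6 nM
- compound 2 `Cn1cncc1C(OCc1ccc(C#N)nc1-c1ccc(OC(F)(F)F)cc1)c1ccc(C#N)cc1` gives 4 nM

Compound 2 stands within the scatter of compound 1, so these two values show no order. Compound 3 `Cn1cncc1C(OCc1ccc(C#N)nc1-c1ccccc1)c1ccc(C#N)cc1` is the next to be read, and the change hydrogen in place of trifluoromethoxy on an aromatic carbon puts hydrogen in place of trifluoromethoxy on an aromatic carbon. Going by the values given here, no measured step between compounds differing in one place is available, so the size remains a judgement. Expected in this assay is a moderate step toward a higher number, a 3.0-fold higher number from compound 2 to compound 3 (0.48 log units; beyond the scatter) in this estimate. For compound 3 the expected value is 12 nM within an estimated range from 3 nM to 50 nM in this assay.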

Compound 3, half-maximal effective concentration: 19 nM
For compound 3 the middle estimate is 1.6-fold (0.20 log units) below the measured one, and the stated range covers the measured number.
By their numbers in this assay, from the lowest: compounds 1 and 2 (each within the scatter of the next); then compound 3.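

In this assay, going by these compounds alone, the change from 4-(trifluoromethoxy)phenyl to phenyl gives a 4.8-fold higher number from compound 2 to compound 3 (0.68 log units; beyond the scatter) and is the first single-place step. It shows that the number responds to the group on this aromatic carbon, para to a large group, and that hydrogen there does not match trifluoromethoxy. The data available give no explanation for this step.

Open, on these data alone, is whether fluorine, chlorine or a methoxy group on this carbon stays with compound 2 or with compound 3. Compound 1 differs from both in more than one place and cannot settle this.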